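The source may report more compounds than this note shows. Statements on the series, on what has been measured and on what is new or still open speak of the compounds shown alone.

Measured compounds:
Compound 1 `Cc1ccc(S(=O)(=O)N2CC(c3nc(-c4cccc(Cl)c4)no3)C2)cc1` gives > 10000 nM in an assay on HEK293 cells for positive allosteric modulation of metabotropic glutamate receptor 5 (Homo sapiens), read by FLIPR; a lower number here means that less compound is needed, a higher number that more compound is needed for the effect; this is a limit of the assay.
Compound 2 `O=S(=O)(c1ccc(F)cc1)N1CC(c2nc(-c3cccc(Cl)c3)no2)C1` gives > 10000 nM in this assay; this is a limit of the assay.
Compound 3 `O=S(=O)(c1ccc(Cl)cc1)N1CC(c2nc(-c3cccc(Cl)c3)no2)C1` gives > 10000 nM in this assay; this is a limit of the assay.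

Compound 1 thus stands only at a limit, and the other two values sit at the same limit (the limit of > 10000 nM in this assay, at which 3 of the 3 values shown sit). The measured steps a step that the two limits leave unreadable from compound 1 to compound 2, a step that the two limits leave unreadable from compound 1 to compound 3 and a step that the two limits leave unreadable from compound 2 to compound 3 are all unreadable, since each joins two limits; none of them shows whether the sulfonyl aryl substituent moves the number at all.

Compound 4 `Cc1ccc(S(=O)(=O)N2CC(c3nc(-c4cccc(C)c4)no3)C2)cc1` is the not yet measured member. Its change from compound 1 is methyl in place of chloro on an aromatic carbon, on the other aryl ring than the one varied in the measured steps. Going by the values given here, no measured step therefore bears directly on it. With every value shown at the limit and no readable step, the expectation for compound 4 in this assay is again a limit, so the step that the limit leaves unreadable from compound 1 to compound 4 is expected to be none beyond the scatter. The estimate for compound 4 is 20000 nM with a range from 5000 nM to 80000 nM.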

Compound 4, half-maximal effective concentration: > 10000 nM
Compound 4: only a limit was reported (the forecaster's own chance of this, stated with the estimate: 85%); the middle value is on the limit's open side.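

The step between compound 1 and compound 4 cannot be read, since both stand only at a limit in this assay: the limit of > 10000 nM in this assay, at which 4 of the 4 values shown sit.

The compounds shown leave open whether a substituent on either aryl ring moves the number in this assay at all.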